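The source may report more compounds than this note shows. Statements on the series, on what has been measured and on what is new or still open speak of the compounds shown alone.

Measured so far:
Compound 1, `COc1ccc(-c2cc(/C=C/C(=O)c3ccc(OC)c(OC)c3)[nH]n2)cc1`: > 100000 nM
Compound 2, `COc1cc(-c2cc(/C=C/C(=O)c3ccc(Cl)c(Cl)c3)[nH]n2)cc(OC)c1OC`: 96000 nM
Compound 3, `COc1ccc(C(=O)/C=C/c2cc(-c3cc(OC)c(OC)c(OC)c3)n[nH]2)cc1`: > 100000 nM

Compound 1 reaches only a limit in a functional assay on SR cells (Homo sapiens) for inhibition, read by sulforhodamine B assay, with a stated time of 48 h (a lower number here means that less compound is tolerated, a higher number that more compound is tolerated), with its value of > 100000 nM being a limit of the assay and not a number. Compound 2 gives 96000 nM in this assay. Compound 3 likewise sits at a limit, and its value of > 100000 nM is a limit rather than a number, so its place among the three is known only as the limit of > 100000 nM in this assay, at which 2 of the 3 values shown sit.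

The step to compound 4, `COc1cc(-c2cc(/C=C/C(=O)c3ccc(F)c(F)c3)[nH]n2)cc(OC)c1OC`, is 3,4-difluorophenyl in place of 4-methoxyphenyl on a carbonyl carbon. Going by the values given here, the one measured step that touches the same place, an at least 1.0-fold higher number from compound 2 to compound 3 (0.01 log units; that floor lies within the scatter), changed the group on the carbonyl carbon and stayed within the scatter. Nothing measured here separates one aryl group on that carbonyl carbon from another, so compound 4 is expected to stay near the limit as well, with a step of a number no higher from compound 3 to compound 4 (the limit leaves the size open). Compound 4 is therefore estimated at 100000 nM, in a range from 40000 nM to 200000 nM, with a good chance that this assay again reports only a limit.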

Compound 4, concentration lethal to 50% of the cells: > 100000 nM
Compound 4 ended at the assay's limit (the forecaster's own chance of this, stated with the estimate: 60%); the middle value sits exactly at the limit.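

Exchanging the halogens on the aryl group gives an at least 1.0-fold higher number from compound 2 to compound 4 (0.01 log units; that floor lies within the scatter), so 3,4-difluorophenyl and 3,4-dichlorophenyl on the carbonyl carbon cannot be told apart in this assay. The step between compound 3 and compound 4 cannot be read, as both values are limits, so 3,4-difluorophenyl and 4-methoxyphenyl cannot be ordered at this place. A third aryl group on this carbonyl carbon thus leaves the picture at the top of the scale, where a limit rather than a number now describes most of the set: the limit of > 100000 nM in this assay, at which 3 of the 4 values shown sit.

From the compounds shown here alone, whether any group on this carbonyl carbon can give a number clearly under that limit stays open. An aryl group carrying an amine or a carboxylic acid might answer this, and so might a longer chain in place of the aryl group.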